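Cytotoxicity Held at the Assay Limit Across a Shared Change

The source may hold more compounds than are shown below. What is called first, only, known or untested is meant among the compounds shown, and "the series" means these compounds.

Compound 1 `O=[N+]([O-])c1cn2c(n1)OC[C@@H](OCc1csc(-c3ccc(F)cc3)n1)C2`: > 128000 nM in an ADME assay on Vero cells (Chlorocebus sabaeus) for cytotoxicity, with a stated time of 72 h; on this read-out higher numbers stand for weaker inhibition and lower numbers for stronger inhibition
Compound 2 `COc1ccc(-c2nc(CO[C@@H]3COc4nc([N+](=O)[O-])cn4C3)cs2)cc1F`: > 128000 nM in this assay
Compound 3 `O=[N+]([O-])c1cn2c(n1)OC[C@@H](OCc1cc(-c3ccc(F)cc3)no1)C2`: > 128000 nM in this assay

Each of these values is a limit of the assay, not a number. The change from compound 1 to compound 2 is 3-fluoro-4-methoxyphenyl in place of 4-fluorophenyl on an aromatic carbon; its step is a step that the two limits leave unreadable from compound 1 to compound 2, because the limit of > 128000 nM in this assay, at which 3 of the 3 values shown sit, hides any movement. The difference between the two cores of compound 1 and compound 3 is not broken down here. Compound 4 `COc1ccc(-c2cc(CO[C@@H]3COc4nc([N+](=O)[O-])cn4C3)on2)cc1F` carries the same kind of change, (3-fluoro-4-methoxyphenyl in place of 4-fluorophenyl on an aromatic carbon), but around a different place. Compound 4 is expected to show a step of a number no higher from compound 3 to compound 4 (the limit leaves the size open), because compound 3 sits at the limit with > 128000 nM and the limit of > 128000 nM in this assay, at which 3 of the 3 values shown sit, holds for every value shown. Compound 4 is estimated at 128000 nM in this assay, most likely again reported as a limit.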

Compound 4, half-maximal inhibitory concentration: > 128000 nM
Compound 4: only a limit was reported (the forecaster's own chance of this, stated with the estimate: 85%); the middle value sits exactly at the limit.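

No step can be read from compound 3 to compound 4, since both values are limits rather than numbers: the limit of > 128000 nM in this assay, at which 4 of the 4 values shown sit. The compounds shown leave open whether 3-fluoro-4-methoxyphenyl in place of 4-fluorophenyl changes the result at all in this assay.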